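The source may hold more compounds than are shown below. What is called first, only, known or untested is meant among the compounds shown, and "the series" means these compounds.

Measured compounds:
compound 1 `O=C(NCCO)c1cccc(Nc2ncc(F)c(Nc3ccc(F)cc3)n2)c1` — 12400 nM
compound 2 `COCC(=O)Nc1cccc(Nc2ncc(F)c(Nc3ccc(F)cc3)n2)c1` — 6250 nM

In a functional assay on KB cells (Homo sapiens) for antiproliferative activity, read by sulforhodamine B assay, with a stated time of 3 days (on this read-out lower numbers stand for stronger inhibition of growth and higher numbers for weaker inhibition of growth), compound 1 gives 12400 nM, the higher of the two numbers; its nearest neighbour is compound 2, and the step from one to the other stays within the scatter: a 2.0-fold lower number from compound 1 to compound 2 (0.30 log units; within the scatter). Compound 3 `CN1CCC(C(=O)Nc2cccc(Nc3ncc(F)c(Nc4ccc(F)cc4)n3)c2)CC1` awaits measurement. It differs from compound 1 in one place: ((1-methylpiperidin-4-yl)carbonyl)amino in place of (2-hydroxyethyl)carbamoyl on an aromatic carbon. Within the data shown here, only one measured step touches that position, the exchange from compound 1 to compound 2, which was a 2.0-fold lower number from compound 1 to compound 2 (0.30 log units; within the scatter); it says that a change of the group on that aromatic carbon can pass without a step beyond the scatter, but nothing is known for a group carrying a six-membered non-aromatic ring. No step beyond the scatter is therefore expected; compound 3 is estimated at 8000 nM, between 2500 nM and 25000 nM, meaning an expected 1.6-fold lower number from compound 1 to compound 3 (0.19 log units; within the scatter).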

Compound 3, concentration for 50% growth inhibition: 1700 nM
Beside the measured number, compound 3's estimate is 4.7-fold (0.67 log units) above it; the measured number lies below the stated range.
By their numbers in this assay, from the lowest: compound 3; then compounds 2 and 1 (each within the scatter of the next).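

In this assay, this aromatic carbon proves sensitive to the group it carries: ((1-methylpiperidin-4-yl)carbonyl)amino in place of (2-hydroxyethyl)carbamoyl gives a 7.3-fold lower number from compound 1 to compound 3 (0.86 log units; beyond the scatter), a step beyond the scatter, which the earlier exchange at this position did not reach. With the carbonyl and amino link held constant, 1-methylpiperidin-4-yl in place of methoxymethyl still gives a 3.7-fold lower number from compound 2 to compound 3 (0.57 log units; beyond the scatter), so the gain also appears when only the group on the carbonyl carbon changes. Nothing available explains either step.

The compounds shown do not separate the ring from its nitrogen: a cyclohexyl or tetrahydropyran-4-yl group on the same carbonyl carbon, or an open-chain dimethylaminomethyl group, would test this. As far as these compounds go, whether the methyl group on the ring nitrogen matters also stays open, and an unsubstituted piperidin-4-yl group would address that.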